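Enantiomer swap at the amide-bearing carbon of compound 2

The compounds below may be only part of what the source reports. "The series", "measured", "known", "first", "only" and "open" are said of these compounds alone.

In an assay on HEK293 cells for antagonist activity at transient receptor potential cation channel subfamily M member 8 (Homo sapiens), read by calcium flux (a lower number here means a stronger inhibitor, a higher number a weaker inhibitor), compound 2 `COc1cccc(CN(C(=O)c2cccs2)[C@H](C(N)=O)c2ccccc2)c1` gives 54000 nM. This is the lowest of the two numbers recorded, and its nearest neighbour is compound 1 `COc1cccc(CN(C(=O)c2ccccc2)[C@@H](C(=O)N(C)C)c2ccccc2)c1`, whose 86000 nM lies within the usual scatter, so neither can be called the stronger. Compound 3 `COc1cccc(CN(C(=O)c2ccccc2)[C@H](C)C(N)=O)c1` reaches only the limit of this assay, > 100000 nM, rather than a number (the limit of > 100000 nM in this assay, at which 1 of the 3 values shown sits). Compound 4 `COc1cccc(CN(C(=O)c2cccs2)[C@@H](C(N)=O)c2ccccc2)c1` has not yet been tested, and it differs from compound 2 as follows: the two compounds have the same atoms and bonds and differ only in configuration as drawn: 1 of 1 stereo elements differ; a stereocentre at a saturated chain carbon is drawn S in compound 2 and R in compound 4. No measured pair shows what such a change does here, and the numbers give no reason to expect a step beyond the scatter in either direction. Compound 4 is therefore expected to give about 60000 nM, within 15000 nM to 200000 nM, the estimated step of a 1.1-fold higher number from compound 2 to compound 4 (0.05 log units; within the scatter).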

Compound 4, half-maximal inhibitory concentration: 1700 nM
Estimate against measurement, compound 4: 35-fold (1.55 log units) above; measured number outside the range, below it.
By their numbers in this assay, from the lowest: compound 4; then compounds 2 and 1 (each within the scatter of the next). At a limit, above all of these: compound 3.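

Drawn R rather than S at the saturated chain carbon, the compound shows a 32-fold lower number from compound 2 to compound 4 (1.50 log units; beyond the scatter) in this assay. Within the data shown here, until this pair, no measured compounds had tested this stereocentre, and the earlier values gave no sign that this position could matter so much. The whole step can be assigned to the stereocentre because nothing else changes: the fact that compounds 2 and 4 differ only in the configuration as drawn

The compounds shown leave open whether the R configuration would give a step of this size with a carboxylic acid in place of the amide. They also do not show what the S and R forms of the other compounds would give.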